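A few compounds are considered here, and "the series" means these few. Any claim that something is new, unique, unknown or untested is made for them only; others in the source may bear on it.

Measured in a functional assay on HCT-116 cells (Homo sapiens) for antiproliferative activity, read by MTT assay, with a stated time of 24 h; on this read-out lower numbers stand for stronger inhibition and higher numbers for weaker inhibition:
compound 1 `COc1cc(OC)c(-c2coc3cc(OCc4ccccc4)ccc3c2=O)cc1OC`: 2280 nM
compound 2 `COc1cc(OC)c(-c2coc3cc(OCc4ccc(F)cc4)ccc3c2=O)cc1OC`: 950 nM

For the measured compounds named here, compound 2, at 950 nM, has the lower of the two numbers so far. The next compound is compound 3 `COc1cc(OC)c(-c2coc3cc(OCc4ccccc4C(F)(F)F)ccc3c2=O)cc1OC`, not yet measured. The change is 2-(trifluoromethyl)phenyl in place of 4-fluorophenyl on a saturated chain carbon bound to an oxygen on an aromatic ring, with 2-(trifluoromethyl)phenyl in place of 4-fluorophenyl on a saturated chain carbon bound to an oxygen on an aromatic ring.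

Going by the values given here, only one measured step bears on this: a 2.4-fold lower number from compound 1 to compound 2 (0.38 log units; beyond the scatter), with fluoro in place of hydrogen on an aromatic carbon. It is modest but beyond the scatter. The 4-fluorophenyl involved in that step leaves in compound 3, so the lower number may not carry over. Among the compounds with values here, no measured compound carries 2-(trifluoromethyl)phenyl, so this single step is a weak guide and the range must stay wide.

A modest move towards a higher number is therefore expected in this assay. The expected step is a 1.6-fold higher number from compound 2 to compound 3 (0.20 log units; within the scatter). For compound 3 the estimate is 1500 nM, with an expected range of 500 nM to 5000 nM.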

Compound 3, half-maximal inhibitory concentration: 4760 nM
For compound 3 the middle estimate is 3.2-fold (0.50 log units) below the measured one; the range from low to high includes it.
By their numbers in this assay, from the lowest: compound 2; then compound 1; then compound 3.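

In this assay, 2-(trifluoromethyl)phenyl in place of 4-fluorophenyl on a saturated chain carbon bound to an oxygen on an aromatic ring gives a 5.0-fold higher number from compound 2 to compound 3 (0.70 log units; beyond the scatter), so a substituent on this aromatic ring does not always bring the number down. Adding trifluoromethyl to this aromatic ring gives a 2.1-fold higher number from compound 1 to compound 3 (0.32 log units; beyond the scatter), which runs opposite to the earlier step with fluoro in place of hydrogen, a 2.4-fold lower number from compound 1 to compound 2 (0.38 log units; beyond the scatter), and shows that the number at this place can move either way with the substituent. No measurement in hand accounts for the difference between the two substituents.

The step from 4-fluorophenyl to 2-(trifluoromethyl)phenyl changes both the substituent and its place on the ring, and the compounds shown cannot separate these two changes. Also open, on these data alone, is how the number responds to groups of another kind, such as an amine or a carboxylic acid on this aromatic ring, or to a longer chain between the oxygen and the ring.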